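Trifluoromethoxy in Place of Ethyl: One Expected Step

This account rests on a few compounds, and the source may have more. Where it says the series, first, only, none or still open, it means among the compounds named here.

Two measured compounds share a core and differ in a single group on an aromatic carbon. Compound 1 `CCCC(=O)Nc1cccc(NC(=O)c2ccccc2F)c1` carries a fluoro there, and in an assay on a cell-free system (plasma) for inhibition of proteinase-activated receptor 1 (Homo sapiens), read by flow cytometry, with a stated time of 20 min (on this read-out higher numbers stand for weaker inhibition and lower numbers for stronger inhibition), compound 1 gives 970 nM. Compound 2 `CCCC(=O)Nc1cccc(NC(=O)c2ccccc2CC)c1` carries an ethyl instead, and in this assay compound 2 gives 520 nM, the number at the low end of the two recorded, although the step of a 1.9-fold lower number from compound 1 to compound 2 (0.27 log units; within the scatter) is within the scatter, so the two compounds cannot be told apart.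

Compound 3 `CCCC(=O)Nc1cccc(NC(=O)c2ccccc2OC(F)(F)F)c1` has not been measured. It differs from compound 2 by trifluoromethoxy in place of ethyl on an aromatic carbon, on an aromatic carbon of a six-membered aromatic ring of carbon only, ortho to a large group. Among the measured compounds shown here, the only measured step at this position is the exchange of fluoro for ethyl, and it stayed within the scatter. For the measured compounds named here, no measured step involves a trifluoromethoxy at all. The expectation for this assay is therefore a step of no size beyond the scatter, a 1.3-fold higher number from compound 2 to compound 3 (0.10 log units; within the scatter). In this assay compound 3 is estimated at 650 nM, with a range from 250 nM to 1700 nM.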

Compound 3, half-maximal inhibitory concentration: 710 nM
The estimate for compound 3 lay 1.1-fold (0.04 log units) below the measured number; the measured number falls inside the stated range.
By their numbers in this assay, from the lowest: compounds 2, 3 and 1 (each within the scatter of the next).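

In this assay, trifluoromethoxy in place of ethyl gives a 1.4-fold higher number from compound 2 to compound 3 (0.14 log units; within the scatter), and trifluoromethoxy in place of fluoro gives a 1.4-fold lower number from compound 1 to compound 3 (0.14 log units; within the scatter). The earlier pair had shown only that fluoro and ethyl could not be told apart on this aromatic carbon, ortho to a large group; now three groups cannot be told apart there, although trifluoromethoxy has more heavy atoms than ethyl and carries a hydrogen-bond acceptor that ethyl lacks. Nothing in the data shown offers an explanation for why the three numbers lie within the scatter of one another.

The compounds shown leave open whether an amine, a carboxylic acid or a longer chain on this same carbon would produce a step beyond the scatter, or whether the assay would continue to give numbers that cannot be separated. They also leave open whether these same three groups would remain indistinguishable elsewhere on the ring, since every step shown here lies at this one position on the shared core.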